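The compounds below may be only part of what the source reports. "The series", "measured", "known", "first", "only" and "open" are said of these compounds alone.

Compound 1 `CCNC(=O)c1noc(-c2cc(C(C)C)c(O)cc2O)c1-c1cc(COCC(N)=O)no1` gives 97 nM in a functional assay on HCT-116 cells (Homo sapiens) for inhibition; on this read-out higher numbers stand for weaker inhibition and lower numbers for stronger inhibition.
Compound 2 `CCNC(=O)c1noc(-c2cc(C(C)C)c(O)cc2O)c1-c1cc(CNCCO)no1` gives 111 nM in this assay.

Compound 2 holds the highest of the two numbers measured, but the step of a 1.1-fold higher number from compound 1 to compound 2 (0.06 log units; within the scatter) is within the scatter, so on this read-out compound 1 and compound 2 cannot be told apart. The next compound, compound 3 `CCNC(=O)c1noc(-c2cc(C(C)C)c(O)cc2O)c1-c1cnn(C)c1`, changes a larger part of the molecule: 1-methyl-1H-pyrazol-4-yl in place of 3-(((2-hydroxyethyl)amino)methyl)-1,2-oxazol-5-yl on an aromatic carbon.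

For the measured compounds named here, the only measured step, a 1.1-fold higher number from compound 1 to compound 2 (0.06 log units; within the scatter), exchanges one group on the saturated chain carbon of the ring that now leaves entirely; it gives no guide to removing that ring and putting a smaller ring with no hydrogen-bond donors in its place. Going by the values given here, no measured step therefore bears directly on this change, and the expectation rests on the size of the change alone. The expected step is a 2.3-fold higher number from compound 2 to compound 3 (0.35 log units; beyond the scatter), a modest loss held with low confidence. Compound 3 is estimated at 250 nM in this assay, with a wide range from 60 nM to 1500 nM.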

Compound 3, half-maximal inhibitory concentration: 41 nM
The estimate for compound 3 lay 6.1-fold (0.79 log units) above the measured number; measured number outside the range, below it.
By their numbers in this assay, from the lowest: compound 3; then compounds 1 and 2 (each within the scatter of the next).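

In this assay, replacing the whole 3-(((2-hydroxyethyl)amino)methyl)-1,2-oxazol-5-yl group with 1-methyl-1H-pyrazol-4-yl gives a 2.7-fold lower number from compound 2 to compound 3 (0.43 log units; beyond the scatter), a modest step that the earlier exchange on the side chain could not have revealed. At this aromatic carbon, then, inhibition does not depend on keeping the leaving group: the entering group has fewer heavy atoms, and 0 hydrogen-bond donors against 2, yet the number falls. Nothing measured here explains that fall, and the ring and its substituent change together, leaving the contribution of each unknown.

Going by these compounds, it remains open whether the methyl matters, as an unsubstituted 1H-pyrazol-4-yl would show. A phenyl ring, or a longer chain such as 2-hydroxyethyl on the pyrazole nitrogen, would test how much else this carbon accepts.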